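The source may hold more compounds than are shown below. What is called first, only, known or untested is meant among the compounds shown, and "the series" means these compounds.

Measured compounds:
- Compound 1, `O=[N+]([O-])c1ccc(-c2nn(-c3ccccc3)cc2-c2nnc(-c3ccc(Cl)cc3)o2)cc1`: 167 mg/kg
- Compound 2, `c1ccc(-c2nn(-c3ccccc3)cc2-c2nnc(-c3ccncc3)o2)cc1`: "not determined" (no result reported)

Two compounds share a common core. In a functional assay on the whole organism for inhibition, with Rattus norvegicus as the target, read by paw edema, with stated times of 1 h and 2 h (a higher number here means that more compound is needed for the effect, a lower number that less compound is needed), compound 1 gives 167 mg/kg. For compound 2 the same assay gives "not determined" (no result reported), so compound 2 stands on no single number at all; there is nothing to place it against compound 1.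

Compound 3, `O=[N+]([O-])c1ccc(-c2nn(-c3ccccc3)cc2-c2nnc(-c3ccncc3)o2)cc1`, has not yet been measured. It differs from compound 2 in one place: nitro in place of hydrogen on an aromatic carbon. Going by the values given here, since compound 2 carries no number, no step from it can be sized, and no step between any two measured compounds has been recorded, so the direction and size of this change cannot be read from the data. Among the compounds with values here, the only measured anchor is compound 1, which also carries the nitro group and gives 167 mg/kg in this assay.

On that basis compound 3 is expected to fall near 170 mg/kg, within a range of about 80 mg/kg to 350 mg/kg.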

Compound 3, dose for half-maximal effect: 72.6 mg/kg
The estimate for compound 3 lay 2.3-fold (0.37 log units) above the measured number; measured number outside the range, below it.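

In this assay, going by these compounds alone, there is a 2.3-fold lower number from compound 1 to compound 3 (0.36 log units; beyond the scatter) when pyridin-4-yl takes the place of 4-chlorophenyl, the first change in this set whose size can be read. With the nitro group held constant, this outer aromatic group on the shared core clearly affects the dose needed, although the step is modest and the effect remains with either group. The data shown offer no measured explanation for this shift.

From the compounds shown here alone, compound 2 has no number, so the step from phenyl to 4-nitrophenyl cannot be read, and what the nitro group itself contributes remains unknown. Also open, going by these compounds, is how an amine or a carboxylic acid in place of the nitro group, or pyridin-3-yl in place of pyridin-4-yl, would read in this test.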